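The source may report more compounds than this note shows. Statements on the series, on what has been measured and on what is new or still open speak of the compounds shown alone.

Of the compounds shown here, three have been measured in a functional assay on MCF7 cells (Homo sapiens) for cytotoxicity, read by MTT assay, with a stated time of 72 h; on this read-out higher numbers stand for weaker inhibition and lower numbers for stronger inhibition. Compound 1 `O=C(Nc1ccc(Oc2ccnc3[nH]ccc23)cc1)c1nn(-c2ccc(Cl)c(F)c2)ccc1=O` gives 3110 nM. Among the measured compounds shown here, compound 2 `O=C(Nc1ccc(Oc2ccnc3[nH]ccc23)c(F)c1)c1nn(-c2ccc(Cl)c(F)c2)ccc1=O` gives 11600 nM, and the one measured step between neighbours, a 3.7-fold higher number from compound 1 to compound 2 (0.57 log units; beyond the scatter), is the only guide to how a small change moves this read-out. Compound 3 `Cc1cc(=O)n(-c2cccc(F)c2)nc1C(=O)Nc1ccc(Oc2ncnc3[nH]ccc23)cc1` gives 9670 nM, the second highest of the three numbers: its value and that of compound 2 sit within the scatter of each other, while compound 1 gives a number lower than compound 3 by more than the scatter.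

Compound 4 `Cc1cc(=O)n(-c2cccc(C(F)(F)F)c2)nc1C(=O)Nc1ccc(Oc2ncnc3[nH]ccc23)cc1` differs from compound 3 by trifluoromethyl in place of fluoro on an aromatic carbon. For the measured compounds named here, no measured step covers this change: the one step available, from compound 1 to compound 2, concerns a different group at a different place, so it says nothing about swapping fluoro for trifluoromethyl here. Going by the values given here, with no bearing step, the expected step of a 1.1-fold lower number from compound 3 to compound 4 (0.03 log units; within the scatter) is none beyond the scatter. Compound 4 is therefore estimated at 9000 nM in this assay, with a range from 3000 nM to 27000 nM.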

Compound 4, half-maximal inhibitory concentration: 4560 nM
Estimate against measurement, compound 4: 2.0-fold (0.30 log units) above; the measured number falls inside the stated range.
By their numbers in this assay, from the lowest: compounds 1 and 4 (each within the scatter of the next); then compounds 3 and 2 (each within the scatter of the next).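

In this assay, replacing fluoro with trifluoromethyl on this aromatic carbon gives a 2.1-fold lower number from compound 3 to compound 4 (0.33 log units; beyond the scatter), the first measured sign that the read-out responds to what sits at this position, meta to a large group. Among the compounds shown here, the change is modest, but it shows that the bulkier-counted 3-(trifluoromethyl)phenyl in place of 3-fluorophenyl keeps the compound active and lowers the number, whereas the only earlier step concerned a different place and cannot speak for this one. No measurement shown gives a reason for this shift.

Whether the trend would continue is open: a nitrile, an amine or a carboxylic acid at this position could move the number either way. It is also unknown whether the same swap would have a similar effect on the core of compound 1.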